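From butyl to cyclopropyl on a shared core

The source may report more compounds than this note shows. Statements on the series, on what has been measured and on what is new or still open speak of the compounds shown alone.

In an ADME assay on HEK-293T cells (Homo sapiens) for cytotoxicity, read by resazurin assay, with a stated time of 16 h (a higher number here means a weaker inhibitor, a lower number a stronger inhibitor), compound 3 (`CCCCNc1nc(NC2CCCC2)nc2c1ncn2[C@@H]1O[C@H](CO)[C@@H](O)[C@H]1O`) gives > 500000 nM as a limit of the assay and not a number. Compound 1 (`OC[C@H]1O[C@@H](n2cnc3c(NC4CCCC4)nc(NC4CCCC4)nc32)[C@H](O)[C@@H]1O`) gives > 500000 nM as a limit too. Compound 2 (`OC[C@H]1O[C@@H](n2cnc3c(N4CCCCC4)nc(NC4CCCC4)nc32)[C@H](O)[C@@H]1O`) carries the entry "not determined" (no result reported) and so offers no guide.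

Compound 4 (`OC[C@H]1O[C@@H](n2cnc3c(NC4CC4)nc(NC4CCCC4)nc32)[C@H](O)[C@@H]1O`) has cyclopropyl in place of butyl on a nitrogen on an aromatic ring. Among the compounds with values here, the one measured step that bears on this swap is a step that the two limits leave unreadable from compound 1 to compound 3 with butyl in place of cyclopentyl on a nitrogen on an aromatic ring. The expectation therefore rests on compound 1 and compound 3 sharing the limit of > 500000 nM in this assay, at which 2 of the 3 values shown sit, and not on any measured step size. In this assay the expected change is a number no higher from compound 3 to compound 4 (the limit leaves the size open) with no step beyond the scatter expected in either direction. For compound 4 the estimated value is 500000 nM with an expected range from 250000 nM to 1000000 nM and the assay will most likely report only a limit.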

Compound 4, half-maximal inhibitory concentration: > 500000 nM
Compound 4 was reported as a limit; the forecaster's own chance of this, stated with the estimate: 85%; the middle value sits exactly at the limit.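

No step can be read among compound 1, compound 3 and compound 4, because each of their values is only a limit of the assay and not a number: the limit of > 500000 nM in this assay, at which 3 of the 4 values shown sit.

The compounds shown leave open whether cyclopentyl, butyl or cyclopropyl on that nitrogen makes any real difference in this assay at all.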